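Bromo on the sulfonyl phenyl of compound 2

The source may hold more compounds than are shown below. What is called first, only, known or untested is meant among the compounds shown, and "the series" means these compounds.

Measured in a functional assay on A549 cells (Homo sapiens) for cytotoxicity, read by MTT assay, with a stated time of 72 h; a higher number here means a weaker inhibitor, a lower number a stronger inhibitor:
compound 1, `COc1cc(Nc2nc3ccccc3nc2S(=O)(=O)c2ccccc2)cc(OC)c1`, compound 1 gives 70 nM
compound 2, `COc1cc(Nc2nc3ccccc3nc2S(=O)(=O)c2ccccc2)cc(OC)c1OC`, compound 2 gives 9660 nM
compound 3, `COc1ccc(S(=O)(=O)c2nc3ccccc3nc2Nc2ccccc2)cc1`, compound 3 gives 13200 nM

Compound 2 sits second highest of the three numbers in this assay. For the measured compounds named here, its nearest neighbour is compound 3, whose number lies within the scatter of that of compound 2; compound 1 lies far below, the one step that reaches compound 2 being a 140-fold higher number from compound 1 to compound 2 (2.14 log units; beyond the scatter).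

Compound 4 is `COc1cc(Nc2nc3ccccc3nc2S(=O)(=O)c2ccc(Br)cc2)cc(OC)c1OC`. It differs from compound 2 in one place: bromo in place of hydrogen on an aromatic carbon. Going by the values given here, the change sits on the sulfonyl phenyl, a ring that no measured step touches: the only step on hand, a 140-fold higher number from compound 1 to compound 2 (2.14 log units; beyond the scatter), concerns the other aromatic ring. Compound 3 carries a methoxy on the sulfonyl phenyl, but it differs from compound 1 in two places, so its value beside that of compound 1 does not separate the two changes. Among the compounds with values here, no measured step therefore bears on the change from compound 2 to compound 4, and in this assay no step beyond the scatter is expected in either direction.

Compound 4 is thus estimated at 9000 nM, between 3000 nM and 30000 nM, the expected step being a 1.1-fold lower number from compound 2 to compound 4 (0.03 log units; within the scatter).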

Compound 4, half-maximal inhibitory concentration: 6110 nM
Compound 4: the middle estimate sits 1.5-fold (0.17 log units) above what was measured, within the range that was stated.
By their numbers in this assay, from the lowest: compound 1; then compounds 4, 2 and 3 (each within the scatter of the next, the first and the last beyond it).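

In this assay, for the compounds shown here, the first single-place change on the sulfonyl phenyl gives a 1.6-fold lower number from compound 2 to compound 4 (0.20 log units; within the scatter) and so leaves compound 2 and compound 4 within the scatter of each other. Going by these compounds alone, this differs in size from the only earlier single-place step, a 140-fold higher number from compound 1 to compound 2 (2.14 log units; beyond the scatter) on the other aromatic ring, and it shows that in the setting of compound 2 a bromo can sit on an aromatic carbon of the sulfonyl phenyl, para to a large group, without a step beyond the scatter. Nothing on hand accounts for this reading.

Going by these compounds, compound 2 already stands far above compound 1, so the reading on this ring is confined to that weak setting, and whether the same bromo gives a similar step on compound 1 at 70 nM in this assay remains open. Also open, on these data alone, is whether another group at this place, such as an amine, a carboxylic acid or a longer chain, would move the number beyond the scatter, as one bromo on one background cannot describe the position as a whole.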